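Compound 1 to compound 4: a larger ether on the core

A few compounds are considered here, and "the series" means these few. Any claim that something is new, unique, unknown or untested is made for them only; others in the source may bear on it.

Compound 1 (`CCOC(=O)N1[C@@H]2C=C[C@@](OC)(C(=O)c3c2cc(OC)c(OC)c3OCC)N1C(=O)OCC`) was examined in an ADME assay on KB cells (Homo sapiens) for cytotoxicity (on this read-out higher numbers stand for an effect only at larger amounts of compound and lower numbers for an effect already at smaller amounts), where compound 1 gives > 300 ug/mL. That entry is a limit of the assay and not a number. Compound 1 therefore stands at the limit of > 300 ug/mL in this assay, at which 2 of the 3 values shown sit. Compound 3 (`COC(=O)N1[C@@H]2C=C[C@@](OC)(C(=O)c3c2cc(OC)c(OC)c3OCc2ccc(OC)cc2)N1C(=O)OC`) likewise gives only a limit, > 300 ug/mL. Compound 2 (`COc1cc2c(c(OCc3ccccc3)c1OC)C(=O)[C@]1(OC)C=C[C@H]2N(C(=O)OCC(C)C)N1C(=O)OCC(C)C`) is the only one of the three with an actual number, 94 ug/mL.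

Compound 4 (`CCOC(=O)N1[C@@H]2C=C[C@@](OC)(C(=O)c3c2cc(OC)c(OC)c3OCc2ccc(Cl)cc2)N1C(=O)OCC`) has not yet been measured. It keeps the core of compound 1 and carries one change, 4-chlorophenyl in place of methyl on a saturated chain carbon bound to an oxygen on an aromatic ring. Cut one bond further out, this reads as ethoxy to (4-chlorobenzyl)oxy.

Going by the values given here, no measured pair isolates this change, so any forecast is tentative. In this assay, among the compounds with values here, a moderate shift towards effects at smaller amounts is expected, beyond the scatter, with compound 2 at 94 ug/mL as the only numerical guide. The expected change is an at least 2.5-fold lower number from compound 1 to compound 4 (0.39 log units; beyond the scatter), and a further limit result remains quite possible. For compound 4 the estimated value is 120 ug/mL, with an expected range from 40 ug/mL to 300 ug/mL.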

Compound 4, concentration for half-maximal effect: 99.9 ug/mL
Beside the measured number, compound 4's estimate is 1.2-fold (0.08 log units) above it, within the range that was stated.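

In this assay, going by these compounds alone, the ether on the core gives the first reading of a single change: 4-chlorophenyl in place of methyl on a saturated chain carbon bound to an oxygen on an aromatic ring gives an at least 3.0-fold lower number from compound 1 to compound 4 (0.47 log units; beyond the scatter). Compound 1 gives a limit and not a number, so the step has a lower bound on its size but no exact size: the limit of > 300 ug/mL in this assay, at which 2 of the 4 values shown sit. The result shows that this one change alone can move the read-out beyond the usual scatter, which compound 1, compound 2 and compound 3 could not show, since they differ from one another in more than one place.

The compounds shown leave open whether the aromatic ring itself or the chlorine on it accounts for the step, and how a plain phenyl, a 4-fluorophenyl or a longer chain would read in the same place. They also leave open whether an amine or a carboxylic acid on that ring would move the number further, or in the opposite direction.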